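The source may hold more compounds than are shown below. What is called first, only, known or untested is meant among the compounds shown, and "the series" means these compounds.

In a functional assay on HCC1806 cells (Homo sapiens) for inhibition, read by sulforhodamine B assay, tested at 10 uM (a higher number here means more inhibition at the concentration tested (going by the name of the read-out), a lower number less inhibition), the measured compounds are: compound 1 `COC(=O)CC(=O)N1N=C(c2ccc(N3CCN(C)CC3)cc2)CC1c1ccc(N(C)C)cc1` with -8.3%; compound 2 `CN1CCN(c2ccc(C3=NN(C(=O)c4ccc(F)cc4)C(c4ccc(N(C)C)cc4)C3)cc2)CC1` with 31.8%; compound 3 `COC(=O)CC(=O)N1N=C(c2ccc(-n3ccnc3)cc2)CC1c1ccc(N(C)C)cc1` with 2.1%.

The change from compound 1 to compound 2, (4-fluorophenyl in place of (methoxycarbonyl)methyl on a carbonyl carbon), produced the step of a number 40.1 percentage points higher from compound 1 to compound 2 (beyond the scatter). Compound 3 differs from compound 1 in its core by 1H-imidazol-1-yl in place of 4-methylpiperazin-1-yl on an aromatic carbon, with the step of a number 10.4 percentage points higher from compound 1 to compound 3 (beyond the scatter), so compound 3 stands second of the three. Compound 4 `CN(C)c1ccc(C2CC(c3ccc(-n4ccnc4)cc3)=NN2C(=O)c2ccc(F)cc2)cc1` carries the same change on the core of compound 3, (4-fluorophenyl in place of (methoxycarbonyl)methyl on a carbonyl carbon), and the place of the change is the same in both pairs. Compound 4 is expected to show a step of similar size, a number 37.9 percentage points higher from compound 3 to compound 4 (beyond the scatter), because the same change once gave a number 40.1 percentage points higher from compound 1 to compound 2 (beyond the scatter). Among the compounds with values here, only one earlier example supports this. Compound 4 is estimated at 40%, between 20% and 60%.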

Compound 4, a percentage reported as inhibition, at one concentration (the size of the read-out at that concentration, not a potency): 7.1%
Compound 4: middle estimate off by 32.9 percentage points, on the high side; the whole stated range lies above it.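

In this assay, putting 4-fluorophenyl in place of (methoxycarbonyl)methyl on the carbonyl carbon gave a number 5 percentage points higher from compound 3 to compound 4 (within the scatter), so the large rise on the core of compound 1 did not carry over to the core of compound 3: the same change on two cores in this assay, a number 40.1 percentage points higher (beyond the scatter) from compound 1 to compound 2 and a number 5 percentage points higher (within the scatter) from compound 3 to compound 4, 35.1 percentage points apart, beyond the scatter of two such steps. Seen from the other place, 1H-imidazol-1-yl in place of 4-methylpiperazin-1-yl gave a number 24.7 percentage points lower from compound 2 to compound 4 (beyond the scatter), and that step does not match its earlier counterpart either: the same change on two cores in this assay, a number 10.4 percentage points higher (beyond the scatter) from compound 1 to compound 3 and a number 24.7 percentage points lower (beyond the scatter) from compound 2 to compound 4, 35.1 percentage points apart, beyond the scatter of two such steps. The two changes therefore do not add up in these four compounds, but this single set of pairs does not show why, nor how far it holds beyond them.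

The compounds shown leave open whether the rise with 4-fluorophenyl needs 4-methylpiperazin-1-yl specifically or would also appear with another amine, such as morpholine, in its place.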